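Shortening the amine substituent on a biaryl core

This account rests on a few compounds, and the source may have more. Where it says the series, first, only, none or still open, it means among the compounds named here.

Compound 3 `CCN(CC)Cc1ccc(Cl)c(-c2ccccc2OC)c1` holds the lowest of the two numbers measured in an assay on isolated protein for binding affinity to 5-hydroxytryptamine receptor 5A (Homo sapiens) (a lower number here means a stronger inhibitor, a higher number a weaker inhibitor), at 230 nM. Its nearest neighbour is compound 2 `CCNCc1ccc(Cl)c(-c2ccccc2OC)c1`, which in this assay gives 1800 nM, a difference of a 7.8-fold lower number from compound 2 to compound 3 (0.89 log units; beyond the scatter). Compound 1 `CCCN(CCC)Cc1ccc(Cl)c(-c2ccccc2OC)c1` sits at a limit of the assay, reported only as > 10000 nM, which is the limit of > 10000 nM in this assay, at which 1 of the 3 values shown sits. From there the moves to the smaller amines were an at least 5.5-fold lower number from compound 1 to compound 2 (0.74 log units; beyond the scatter) and an at least 43-fold lower number from compound 1 to compound 3 (1.63 log units; beyond the scatter).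

The next compound is compound 4 `CCCNCc1ccc(Cl)c(-c2ccccc2OC)c1`, which differs from compound 3 by propylamino in place of diethylamino on a saturated chain carbon bound to an aromatic carbon. Two of the measured steps bear on it. The step of a 7.8-fold lower number from compound 2 to compound 3 (0.89 log units; beyond the scatter) shows that replacing the amine hydrogen with ethyl lowered the number by a modest margin, so removing an ethyl and leaving a secondary amine would be expected to raise it again. The step of an at least 43-fold lower number from compound 1 to compound 3 (1.63 log units; beyond the scatter) shows that lengthening both chains by one carbon raised the number by a large margin, and compound 4 carries one chain lengthened to propyl. Together these point to a modest to large rise in this assay for compound 4, expected as an 11-fold higher number from compound 3 to compound 4 (1.04 log units; beyond the scatter). Compound 4 is therefore estimated at 2500 nM, within a range of 800 nM to 8000 nM.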

Compound 4, inhibition constant: 120 nM
For compound 4 the middle estimate is 21-fold (1.32 log units) above the measured one; the measured number lies below the stated range.
By their numbers in this assay, from the lowest: compounds 4 and 3 (each within the scatter of the next); then compound 2. At a limit, above all of these: compound 1.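

Within the data shown here, at this position, the step of a 1.9-fold lower number from compound 3 to compound 4 (0.28 log units; within the scatter) means that propylamino and diethylamino cannot be told apart in this assay, so a tertiary amine is not required for a number in this range, as the earlier compounds might have suggested. Among the two compounds with a hydrogen left on the amine nitrogen, going from ethylamino to propylamino gives a 15-fold lower number from compound 2 to compound 4 (1.18 log units; beyond the scatter) and so adds a second route to a low number, one that compounds 1 to 3 did not show, where the longer chains of compound 1 went with a much higher number than the ethyl chains of compound 3. Taking one propyl off dipropylamino gives an at least 83-fold lower number from compound 1 to compound 4 (1.92 log units; beyond the scatter) and places the loss in these compounds with the second propyl rather than with propyl itself, though this step rests on a limit for compound 1: the limit of > 10000 nM in this assay, at which 1 of the 4 values shown sits.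

Going by these compounds, it remains open whether a butylamino group on the same carbon would continue the drop seen from ethylamino to propylamino or reverse it. Also open, on these data alone, is how a mixed tertiary amine such as N-ethyl-N-propylamino, or a ring amine such as pyrrolidine, would compare with propylamino and diethylamino.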